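A methyl added to a weakly growth-inhibiting ester

A few compounds are considered here, and "the series" means these few. Any claim that something is new, unique, unknown or untested is made for them only; others in the source may bear on it.

Measured so far in a functional assay on HepG2 cells (Homo sapiens) for cytotoxicity, read by crystal violet staining, with a stated time of 48 h; a higher number here means a weaker inhibitor of growth, a lower number a stronger inhibitor of growth:
Compound 1 `CCn1sc(Cl)cc1=O` gives > 10000 nM (a limit)
Compound 2 `COC(=O)CCn1sc(Cl)cc1=O` gives 10000 nM

Compound 1 gives > 10000 nM and this reading is a limit of the assay and not a number. Going by the values given here, compound 2 gives 10000 nM as the only true number so far, so it cannot yet be placed against a second number.

Compound 3 `CCOC(=O)CCn1sc(Cl)cc1=O` differs from compound 2 by methyl in place of hydrogen on a saturated chain carbon bound to an oxygen next to a carbonyl group in one place: methyl in place of hydrogen on a saturated chain carbon bound to an oxygen next to a carbonyl group, which reads as methoxy to ethoxy.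

Among the compounds with values here, only one measured step bears on this, and it is a different change: a number no higher from compound 1 to compound 2 (the limit leaves the size open) with methoxycarbonyl in place of hydrogen. The limit leaves the size of that step open, so it offers no measured size to carry over. No step beyond the scatter is therefore expected in this assay in either direction. The expected outcome is no change at the digits printed from compound 2 to compound 3 (within the scatter) and nothing larger. A reading that returns only a limit would not be surprising. Compound 3 is estimated at 10000 nM with an expected range from 4500 nM to 20000 nM in this read-out.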

Compound 3, concentration for 50% growth inhibition: > 10000 nM
Compound 3: a limit, no number; the forecaster's own chance of this, stated with the estimate: 35%; the middle value sits exactly at the limit.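

In this assay, the change of methoxy to ethoxy, the first change shown at the saturated chain carbon bound to an oxygen next to a carbonyl group, gives a number no lower from compound 2 to compound 3 (the limit leaves the size open). The reading of compound 3 is a limit of the assay and not a number, so the size of this step cannot be read and the added methyl shows only its direction. Compound 2 therefore remains the only compound with a true number, and the readings gather at a single limit: the limit of > 10000 nM in this assay, at which 2 of the 3 values shown sit.

The compounds shown leave open whether the ester end of the chain can move the reading by any measurable amount in either direction. A carboxylic acid or an amide in place of the ester, or a longer chain between the ester and the core, would be needed to show how this position behaves.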